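An amide in place of butyl on the pyridine core

The source may hold more compounds than are shown below. What is called first, only, known or untested is meant among the compounds shown, and "the series" means these compounds.

Three compounds measured in an assay on membranes from brain for displacement of a labelled ligand from Neuronal acetylcholine receptor; alpha4/beta2 (Rattus norvegicus) (a higher number here means a weaker inhibitor, a lower number a stronger inhibitor), frame this step. Compound 1 `CN1CCC[C@H]1COc1cccnc1[N+](=O)[O-]` gives 9000 nM, and compound 2 `CCN(CC)C(=O)c1ccncc1OC[C@@H]1CCCN1C` gives 2830 nM. Compound 3 `CCCCc1cncc(OC[C@@H]2CCCN2C)c1` stands lowest of the three in this assay with 0.16 nM; its gap to compound 2, the nearest of the others, and its gap to compound 1, the furthest, are both beyond the scatter, so compound 3 is the strongest inhibitor of the three.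

Compound 4 `CN1CCC[C@H]1COc1cncc(C(=O)N2CCCC2)c1` has not yet been measured in this assay. Its structure differs from compound 3 in one place: (pyrrolidin-1-yl)carbonyl in place of butyl on an aromatic carbon. Among the compounds with values here, no measured pair shows exactly this change, so its effect can only be judged from the compounds at hand. Compound 2, which carries a carbonyl-linked amine on its core, gives 2830 nM, a number far higher than that of compound 3, although compound 2 differs from compound 3 in more than this one group.

On that basis compound 4 is expected to lose binding relative to compound 3, and the step from compound 3 to compound 4 is estimated at a 190-fold higher number from compound 3 to compound 4 (2.27 log units; beyond the scatter). The inhibition constant of compound 4 in this assay is estimated at 30 nM, within a range of 3 nM to 300 nM.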

Compound 4, inhibition constant: 19.9 nM
Estimate against measurement, compound 4: 1.5-fold (0.18 log units) above, within the range that was stated.
By their numbers in this assay, from the lowest: compound 3; then compound 4; then compound 2; then compound 1.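

In this assay, within the data shown here, this is the first reading of a single change at this position, on the aromatic carbon two atoms from the ring nitrogen: (pyrrolidin-1-yl)carbonyl in place of butyl gives a 120-fold higher number from compound 3 to compound 4 (2.09 log units; beyond the scatter), a large step beyond the scatter. The position therefore responds strongly to this exchange, which replaces a chain with no ring and no hydrogen-bond acceptor by a group holding a five-membered non-aromatic ring and one hydrogen-bond acceptor, yet binding is not lost altogether, as compound 4 still gives 19.9 nM in this assay. Nothing available bears on why the number rises across this step.

Among these compounds, the single step joins several differences at once, the carbonyl, the ring nitrogen and the ring itself, so the share of each in the rise remains unknown. A ketone such as acetyl, a primary amide or an open-chain amine at this position would begin to separate these parts, while a propyl or hexyl chain would show how closely the low number of compound 3 depends on the length of butyl.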